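A few compounds are considered here, and "the series" means these few. Any claim that something is new, unique, unknown or untested is made for them only; others in the source may bear on it.

In an ADME assay on CCRF-CEM cells (Homo sapiens) for metabolic stability, read by HPLC, at 37 degrees C (a lower number here means that the compound disappears faster, a higher number that the compound lasts longer), three compounds sharing one core have been measured. Compound 1 (`CCCCCCCCCC(=O)Oc1ccc(COP(=O)(O)OP(=O)(O)OC[C@H]2O[C@@H](n3cc(C)c(=O)[nH]c3=O)C[C@@H]2N=[N+]=[N-])cc1`) gives 0.833 h, compound 2 (`CCCCCCCC(=O)Oc1ccc(COP(=O)(O)OP(=O)(O)OC[C@H]2O[C@@H](n3cc(C)c(=O)[nH]c3=O)C[C@@H]2N=[N+]=[N-])cc1`) gives 1.65 h, and compound 3 (`Cc1cn([C@H]2C[C@H](N=[N+]=[N-])[C@@H](COP(=O)(O)OP(=O)(O)OCc3ccc(OC(=O)c4ccc(C(F)(F)F)cc4)cc3)O2)c(=O)[nH]c1=O`) gives 3.83 h, the highest number of the three. The a 2.0-fold higher number from compound 1 to compound 2 (0.30 log units; within the scatter) lies within the scatter, so compound 1 and compound 2 cannot be told apart. Compound 3 stands clear of both, with a 4.6-fold higher number from compound 1 to compound 3 (0.66 log units; beyond the scatter) and a 2.3-fold higher number from compound 2 to compound 3 (0.37 log units; beyond the scatter), each beyond the scatter and modest.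

Compound 4 (`CCCCCCCCCCCC(=O)Oc1ccc(COP(=O)(O)OP(=O)(O)OC[C@H]2O[C@@H](n3cc(C)c(=O)[nH]c3=O)C[C@@H]2N=[N+]=[N-])cc1`) has undecyl in place of 4-(trifluoromethyl)phenyl on a carbonyl carbon. The two modest steps to compound 3 bear most directly on this change when read backwards, since each relates that same group to an unbranched chain. Going by the values given here, no step among the measured compounds tests undecyl itself. A modest fall in this assay is therefore expected, close to the larger of those two steps, a 4.6-fold higher number from compound 1 to compound 3 (0.66 log units; beyond the scatter). The expected change is a 5.1-fold lower number from compound 3 to compound 4 (0.71 log units; beyond the scatter). Compound 4 is estimated at 0.75 h, with an expected range from 0.35 h to 1.6 h.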

Compound 4, half-life: 1.05 h
The estimate for compound 4 lay 1.4-fold (0.15 log units) below the measured number; the measured number falls inside the stated range.
By their numbers in this assay, from the lowest: compounds 1, 4 and 2 (each within the scatter of the next); then compound 3.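

In this assay, undecyl in place of 4-(trifluoromethyl)phenyl on a carbonyl carbon gives a 3.6-fold lower number from compound 3 to compound 4 (0.56 log units; beyond the scatter), so a third unbranched chain also falls modestly short of compound 3. Among the chains themselves, the steps are a 1.6-fold lower number from compound 2 to compound 4 (0.20 log units; within the scatter) and a 1.3-fold higher number from compound 1 to compound 4 (0.10 log units; within the scatter), so undecyl cannot be told apart from heptyl or nonyl at this position, and the three chain compounds form one group beneath compound 3. Nothing available accounts for the gap between the chains and the ring-bearing group.

The compounds shown leave open whether the higher number of compound 3 goes with the aromatic ring or with its trifluoromethyl group. They also leave open whether a plain phenyl or a shorter chain such as propyl on the same carbonyl carbon would stand with compound 3 or with the chains.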